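A few compounds are considered here, and "the series" means these few. Any claim that something is new, unique, unknown or untested is made for them only; others in the source may bear on it.

In an assay on CHO cells for displacement of a labelled ligand from adenosine receptor A3 (Homo sapiens), read by scintillation counting, with a stated time of 45 min, tested at 1 uM, in the presence of a further agent that is not named here (a lower number here means less inhibition, a higher number more inhibition at the concentration tested (going by the name of the read-out)), compound 1 `CCCn1c(=O)[nH]c2nc(-c3ccc(S(=O)(=O)N4CCN(c5ccc(Br)cc5)CC4)cc3)[nH]c2c1=O` gives 29%, the higher of the two numbers measured, but its nearest neighbour compound 2 `CCCn1c(=O)[nH]c2nc(-c3ccc(S(=O)(=O)N4CCN(Cc5cccc(Br)c5)CC4)cc3)[nH]c2c1=O` gives 23%, and the step of a number 6 percentage points lower from compound 1 to compound 2 (within the scatter) lies within the scatter. Compound 3 `CCCn1c(=O)[nH]c2nc(-c3ccc(S(=O)(=O)N4CCN(c5cccc(Br)c5)CC4)cc3)[nH]c2c1=O` differs from compound 1 in one place: 3-bromophenyl in place of 4-bromophenyl on an amine nitrogen in a ring. Within the data shown here, the only measured step that bears on this change is the one a number 6 percentage points lower from compound 1 to compound 2 (within the scatter), which also altered the bromine-bearing group on the same ring nitrogen without moving the number beyond the scatter. No step beyond the scatter is therefore expected for compound 3 either. Compound 3 is expected to give about 26%, with a likely range from 12% to 40%. The expected step from compound 1 is a number 3 percentage points lower from compound 1 to compound 3 (within the scatter).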

Compound 3, a percentage reported as inhibition, at one concentration (the size of the read-out at that concentration, not a potency): 27%
Compound 3: middle estimate off by 1 percentage points, on the low side, within the range that was stated.
By their numbers in this assay, from the lowest: compounds 2, 3 and 1 (each within the scatter of the next).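

In this assay the swap of 4-bromophenyl for 3-bromophenyl on the ring nitrogen, which joins the same atoms differently, is a number 2 percentage points lower from compound 1 to compound 3 (within the scatter) and so shows no readable effect of where the bromine sits on that ring. Set against 3-bromobenzyl, the same 3-bromophenyl group gives a number 4 percentage points higher from compound 2 to compound 3 (within the scatter) and so adds a second comparison with no readable effect. Nothing measured here explains these small differences. Still open, going by these compounds, is whether a group without bromine on that nitrogen, such as a plain phenyl, a carboxylic acid-bearing phenyl or a longer chain, would give a step beyond the scatter.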